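The source may report more compounds than this note shows. Statements on the series, on what has been measured and on what is new or still open speak of the compounds shown alone.

Measured so far:
- compound 1, `CC1=NN(C(=O)COc2ccc(Cl)cc2)C(c2cc(Br)ccc2O)C1`: "not active" (no number reported)
- compound 2, `CC(=O)Oc1ccccc1C1CC(C)=NN1C(=O)CN1CCC(O)CC1`: 12300 nM
- compound 3, `CCC(=O)N1N=C(c2cc3ccccc3oc2=O)CC1c1ccccc1`: 9610 nM

Among the compounds with values here, in a functional assay on HepG2 cells (Homo sapiens) for cytotoxicity, read by MTT assay, with a stated time of 48 h (on this read-out lower numbers stand for stronger inhibition and higher numbers for weaker inhibition), only two compounds come with a number. Compound 1 was reported as not active, and no value was attached to it. Compound 2 gives 12300 nM in this assay, and compound 3 gives 9610 nM. The gap between compound 2 and compound 3 is within the scatter, so the two cannot be told apart on these numbers; compound 3 simply carries one of the two reported values, both in the same weak range.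

Compound 4, `Cc1ccc(S(=O)(=O)N2N=C(c3cc4ccccc4oc3=O)CC2c2ccccc2)cc1`, is built from compound 3 by one change: (4-methylphenyl)sulfonyl in place of propanoyl on an amine nitrogen in a ring. The shared core, the coumarin-bearing part and the phenyl group stay as they are. Within the data shown here, no step between measured compounds involves such a swap, so there is nothing in hand to say how large its effect will be. The expectation is therefore a step near the scatter, a 1.2-fold lower number from compound 3 to compound 4 (0.08 log units; within the scatter), leaning slightly toward a lower number. Compound 4 is estimated at 8000 nM, with a likely range from 2500 nM to 25000 nM.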

Compound 4, half-maximal inhibitory concentration: "not active" (no number reported)
Compound 4 has no reported number here; no gap can be computed for the estimate.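

Within the data shown here, compound 4 carries no number in this assay, only the report "not active" , so no step from compound 3 can be read. Nothing available explains this result. The compounds shown leave open how far (4-methylphenyl)sulfonyl in place of propanoyl shifts the value.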